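From hydroxy to methoxy on a shared core

The source may hold more compounds than are shown below. What is called first, only, known or untested is meant among the compounds shown, and "the series" means these compounds.

In a functional assay on SF-295 cells (Homo sapiens) for antiproliferative activity, read by sulforhodamine B assay, with a stated time of 48 h (on this read-out lower numbers stand for stronger inhibition of growth and higher numbers for weaker inhibition of growth), compound 1 (`O=C(NCCCNc1cc(-c2cn(-c3ccccc3)nc2-c2cccc(O)c2)ccn1)Nc1ccc(F)cc1`) gives 4840 nM and compound 2 (`O=C(NCCCNc1cc(-c2cn(-c3ccccc3)nc2-c2cccc(O)c2)ccn1)Nc1cccc(C(F)(F)F)c1`) gives 6420 nM, so the two values do not separate. Compound 3 (`COc1cccc(-c2nn(-c3ccccc3)cc2-c2ccnc(NCCCNC(=O)Nc3ccc(F)cc3)c2)c1`) differs from compound 1 by methyl in place of hydrogen on an oxygen on an aromatic ring, which turns 3-hydroxyphenyl into 3-methoxyphenyl. Going by the values given here, no measured step covers this change directly. Among the compounds with values here, the one step available, a 1.3-fold higher number from compound 1 to compound 2 (0.12 log units; within the scatter), puts 3-(trifluoromethyl)phenyl in place of 4-fluorophenyl on an amide-type nitrogen, so it bears on the new change only indirectly. It offers no evidence for a large move, and no step beyond the scatter is expected in this assay. The estimate amounts to a 1.2-fold higher number from compound 1 to compound 3 (0.09 log units; within the scatter), and this direction is only tentatively expected. For compound 3 the expected value is 6000 nM, with an estimated range from 2500 nM to 15000 nM.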

Compound 3, concentration for total growth inhibition: 21700 nM
Beside the measured number, compound 3's estimate is 3.6-fold (0.56 log units) below it, and the stated range ends below it.
By their numbers in this assay, from the lowest: compounds 1 and 2 (each within the scatter of the next); then compound 3.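

In this assay, going by these compounds alone, the methyl placed on the oxygen of the 3-hydroxyphenyl group gives a 4.5-fold higher number from compound 1 to compound 3 (0.65 log units; beyond the scatter), which means weaker inhibition of growth and is the only step here beyond the scatter. Within the data shown here, the change on the amide-type nitrogen, by contrast, gives a 1.3-fold higher number from compound 1 to compound 2 (0.12 log units; within the scatter), so the hydrogen on this oxygen is the first place where a single change separates two compounds. Nothing shown here explains the shift.

The compounds shown leave open whether an ethoxy group, or an amine or a fluorine in place of the hydroxy, would stand nearer to compound 1 or to compound 3. From the compounds shown here alone, it also remains open whether the same hydroxy to methoxy change would give a similar step on the 3-(trifluoromethyl)phenyl urea of compound 2.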